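This account rests on a few compounds, and the source may have more. Where it says the series, first, only, none or still open, it means among the compounds named here.

Measured so far in a physicochemical assay for lipophilicity; on this read-out lower numbers stand for lower lipophilicity and higher numbers for higher lipophilicity:
compound 1, `CC(/C=C/CC(C)CCCC(C)C)=C\C(=O)O`: 5.95
compound 2, `COC(C)(C)CCCC(C)C/C=C/C(C)=C/C(=O)OCCC(C)C`: 7.03
compound 3, `CCOC(=O)/C=C(C)/C=C/CC(C)CCC1OC1(C)C`: 4.76

Among these three, compound 2 stands highest in this assay. Its nearest neighbour is compound 1, whose value lies beyond the scatter below it, and compound 3 lies still further down, also beyond the scatter. Among the measured compounds shown here, no single-point step between measured compounds is available, so what follows rests on the structural change alone.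

Compound 4, `CCC(=O)/C=C(C)/C=C/CC(C)CCCC(C)(C)OC`, is not yet measured. It differs from compound 2 in one place:
ethyl in place of isopentyloxy on a carbonyl carbon
The change removes a longer, oxygen-containing chain and puts a shorter, all-carbon chain in its place on the carbonyl carbon. On the numbers this assay produces, such a loss of heavy atoms is expected to lower the value, and the step from compound 2 is expected to be well beyond the scatter, downward, a number 2.03 log units lower from compound 2 to compound 4 (beyond the scatter). Compound 4 is therefore expected to give about 5 in this assay, somewhere between 4.4 and 5.6.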

Compound 4, partition coefficient: 5.07
Compound 4: middle estimate off by 0.07 log units, on the low side, and the stated range covers the measured number.
By their numbers in this assay, from the lowest: compound 3; then compound 4; then compound 1; then compound 2.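

In this assay, the change on the carbonyl carbon now has a measured size: replacing isopentyloxy with ethyl gives a number 1.96 log units lower from compound 2 to compound 4 (beyond the scatter) and marks a large downward step. This is the first step shown between compounds that differ in one place, which the earlier compounds could not provide, and it describes this one pair only. No measurement shown accounts for the step.

The compounds shown leave open how much of the step goes with the shorter chain and how much with the oxygen that leaves, since the change alters both at once. An isopentyl chain on the same carbonyl carbon would keep the longer chain without that oxygen, while a diethylamino group there would show how a nitrogen-linked group compares.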